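Capping a Pyrazole Nitrogen with Acetyl

This account rests on a few compounds, and the source may have more. Where it says the series, first, only, none or still open, it means among the compounds named here.

compound 1, `CNC(=O)N1CCCc2ccc(NC(=O)c3ccc(-c4cc[nH]n4)cc3)cc21`: 92.5%
compound 2, `CNC(=O)N1CCCc2ccc(NC(=O)c3cccc(-c4cnn(C)c4)c3)cc21`: 71.2%

In a functional assay on MV4-11 cells (Homo sapiens) for antiproliferative activity, with a stated time of 6 days, tested at 1.56 uM (on this read-out lower numbers stand for a weaker effect and higher numbers for a stronger effect at the one concentration tested), compound 1 gives 92.5%, the higher of the two numbers, while compound 2 gives 71.2%, a gap beyond the usual scatter. Compound 3, `CNC(=O)N1CCCc2ccc(NC(=O)c3ccc(-c4ccn(C(C)=O)n4)cc3)cc21`, has not been measured yet. It differs from compound 1 by acetyl in place of hydrogen on an aromatic nitrogen. Within the data shown here, no measured pair shows this particular change, so there is no direct guide to its size. A small step is expected, either none beyond the scatter or a modest drop, as a number 8.5 percentage points lower from compound 1 to compound 3 (within the scatter) expresses. Compound 3 is expected to give about 84%, within 60% to 97%.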

Compound 3, a percentage reported as inhibition, at one concentration (the size of the read-out at that concentration, not a potency): 35.8%
Beside the measured number, compound 3's estimate is 48.2 percentage points above it, and the stated range ends above it.
By their numbers in this assay, from the lowest: compound 3; then compound 2; then compound 1.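

In this assay the read-out shows a number 56.7 percentage points lower from compound 1 to compound 3 (beyond the scatter) when acetyl replaces the hydrogen on the aromatic nitrogen, a large step. This position of the pyrazole is therefore sensitive to change: a group of only 3 heavy atoms on this nitrogen costs much of the effect seen at the single concentration tested. Nothing available here explains the loss. Still open, going by these compounds, is whether this drop is specific to acetyl or would also appear with ethyl or a longer chain such as propanoyl on the same nitrogen.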